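The source may report more compounds than this note shows. Statements on the series, on what has been measured and on what is new or still open speak of the compounds shown alone.

Compound 1, `COc1c(Nc2ccc(C#N)cc2Cl)ncnc1OC1C2COCC1CN(C(=O)OC1(C)CC1)C2`, is a glucose-dependent insulinotropic receptor agonist that in a functional assay on HEK293 cells for agonist activity at Glucose-dependent insulinotropic receptor (Homo sapiens), read by fluorescence and cAMP accumulation, with a stated time of 30 min (on this read-out higher numbers stand for larger maximal responses and lower numbers for smaller maximal responses), reaches 88%. Among the entries with a single number it stands lowest of the two: compound 2, `COc1c(Nc2ccc(C#N)cc2F)ncnc1OC1C2COCC1CN(C(=O)OC1(C)CC1)C2`, gives 99% in this assay, and the step of a number 11 percentage points higher from compound 1 to compound 2 (beyond the scatter) comes with fluoro in place of chloro on an aromatic carbon. Compound 3, `Cc1c(Nc2ccc(C#N)cc2Cl)ncnc1OC1CC2COCC(C1)N2C(=O)OC(C)(C)C`, was measured more than once, and its entries, 54%; 38% (2 entries), scatter about a value well under that of compound 1; the repeated entries the several entries of compound 3 in this assay, 54%; 38% (2 entries) show that the lower reading is not a single outlier. Among the compounds with values here, no step between compound 3 and the other two is computed, since they differ in more than one place.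

Compound 4, `Cc1c(Nc2ccc(C#N)cc2Cl)ncnc1OC1C2COCC1CN(C(=O)OC1(C)CC1)C2`, differs from compound 1 by methyl in place of methoxy on an aromatic carbon. No measured step isolates this change, so the only bearing comes from compound 3, which also carries methyl at that carbon and shows the weaker maximal responses given above. On that footing a reduction of the maximal response in this assay is expected for compound 4, and the step of a number 16 percentage points lower from compound 1 to compound 4 (beyond the scatter) is estimated as moderate rather than large. Compound 4 is therefore expected to reach about 72%, with a range from 48% to 95%.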

Compound 4, largest response reached (reported as percent of maximum), in percent of the reference or control that the assay uses in the Glucose-dependent insulinotropic receptor assay: 74%
Estimate against measurement, compound 4: 2 percentage points below; the range from low to high includes it.
By their numbers in the Glucose-dependent insulinotropic receptor assay, from the lowest: compound 4; then compound 1; then compound 2.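

In the Glucose-dependent insulinotropic receptor assay the change at the carbon ortho to a (2-chloro-4-cyanophenyl)amino group now stands alone on the core of compound 1, which compound 3 could not offer, since it carries methyl but differs elsewhere as well; the result is a number 14 percentage points lower from compound 1 to compound 4 (beyond the scatter), so compound 4 keeps much of the maximal response without the methoxy group. The same pair also gives a second read-out: in a physicochemical assay for solubility, at pH 7.4 (a lower number here means a less soluble compound, a higher number a more soluble compound), compound 1 gives 30000 nM and compound 4 gives 6000 nM, which is a 5.0-fold lower number from compound 1 to compound 4 (0.70 log units; beyond the scatter). On both read-outs, then, compound 1 with its methoxy group stands above compound 4 with its methyl group, and the swap brings no gain on either.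

On these data alone, with only methoxy and methyl to compare at this carbon, it remains open whether an ethoxy group, an amino group or a chlorine atom would hold both the maximal response and the solubility of compound 1. The compounds shown also leave open whether the fluoro in place of chloro step seen with methoxy would carry over to the methyl compound, and they give no reason for either shift.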